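This account rests on a few compounds, and the source may have more. Where it says the series, first, only, none or still open, it means among the compounds named here.

In an ADME assay on Vero cells (Chlorocebus sabaeus) for cytotoxicity, read by MTT assay (a lower number here means that less compound is tolerated, a higher number that more compound is tolerated), the series shares one core and varies the group on the sulfonyl sulfur. Compound 1 (`Cn1nc(C(F)(F)F)cc1C(=O)Nc1ccc(S(=O)(=O)N2CCCCCC2)cc1`) gives > 300000 nM, which is a limit of the assay and not a number. Compound 2 (`Cn1nc(C(F)(F)F)cc1C(=O)Nc1ccc(S(=O)(=O)N2CCC(NC(=O)OC(C)(C)C)CC2)cc1`) gives > 300000 nM, also a limit. For the measured compounds named here, compound 3 (`Cn1nc(C(F)(F)F)cc1C(=O)Nc1ccc(S(=O)(=O)N2CCNCC2)cc1`) gives 126000 nM, the only true number in the set, so it has no measured neighbour to be ranked against exactly.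

Compound 4 (`Cn1nc(C(F)(F)F)cc1C(=O)Nc1ccc(S(=O)(=O)N2CCC(N)CC2)cc1`) has 4-aminopiperidin-1-yl in place of piperazin-1-yl on a sulfonyl sulfur. Going by the values given here, only one measured step bears on this change, and it does so indirectly. It is an at least 2.3-fold lower number from compound 1 to compound 3 (0.37 log units; beyond the scatter), where piperazin-1-yl replaced azepan-1-yl. Its size is only a bound, as compound 1 sits at a limit, and it describes the arrival of piperazin-1-yl rather than its exchange for 4-aminopiperidin-1-yl. Among the compounds with values here, compound 2 gives no measured step at all. Taking compound 3 at 126000 nM as the anchor, no step beyond the scatter is expected in this assay, and no direction can be favoured with confidence. The expected change is a 1.1-fold lower number from compound 3 to compound 4 (0.02 log units; within the scatter). For compound 4 the estimated value is 120000 nM, with an expected range from 55000 nM to 260000 nM.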

Compound 4, half-maximal cytotoxic concentration: > 300000 nM
Compound 4: only a limit was reported; the forecaster's own chance of this, stated with the estimate: 20%; at least 2.5-fold (0.39 log units) between middle value and limit.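

In this assay, the exchange of piperazin-1-yl for 4-aminopiperidin-1-yl on the sulfonyl sulfur gives an at least 2.3-fold higher number from compound 3 to compound 4 (0.37 log units; beyond the scatter), so a second step at this position now separates compound 3 from a neighbour, and this time the incoming group also carries an amine. Both groups count 1 hydrogen-bond donor and 1 hydrogen-bond acceptor and neither has a net charge, so these counts alone do not set compound 3 apart from compound 4. Compound 3 remains the only compound with a true number, and the steps to compound 4 from compound 1 and from compound 2 cannot be read, because all three of those compounds sit at one limit of the assay: the limit of > 300000 nM in this assay, at which 3 of the 4 values shown sit.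

The compounds shown leave open how far compound 1, compound 2 and compound 4 each lie from that limit, and so how they rank among themselves. They also leave open whether the lower number stays with other groups on the sulfonyl sulfur, such as 4-methylpiperazin-1-yl or morpholin-4-yl, or is confined to piperazin-1-yl.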